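Pyrrolidine Amide Replacing the Cyclohexylamide: Expected Potency

The source may report more compounds than this note shows. Statements on the series, on what has been measured and on what is new or still open speak of the compounds shown alone.

Measured compounds:
compound 1, `CCN(CC)S(=O)(=O)c1ccc(S(=O)(=O)N2CCC[C@@H](C(=O)N[C@H]3CC[C@H](OC)CC3)C2)cc1`, 1350 nM
compound 2, `CCN(CC)S(=O)(=O)c1ccc(S(=O)(=O)N2CCC[C@@H](C(=O)N3CCC(C(F)(F)F)CC3)C2)cc1`, 320 nM
compound 3, `CCN(CC)S(=O)(=O)c1ccc(S(=O)(=O)N2CCC[C@@H](C(=O)N[C@H]3CC[C@@H](OC)CC3)C2)cc1`, 960 nM

In a functional assay on MIA PaCa-2 cells (Homo sapiens) for inhibition, read by MTT assay, with a stated time of 7 days (a lower number here means a stronger inhibitor, a higher number a weaker inhibitor), compound 3 stands second highest of the three numbers. Its nearest neighbour is compound 1: a 1.4-fold lower number from compound 1 to compound 3 (0.15 log units; within the scatter), and the fact that compounds 1 and 3 differ only in the configuration as drawn explains that these two share every atom and bond. Its furthest is compound 2: a 3.0-fold higher number from compound 2 to compound 3 (0.48 log units; beyond the scatter).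

Compound 4, `CCN(CC)S(=O)(=O)c1ccc(S(=O)(=O)N2CCC[C@@H](C(=O)N3CC[C@H](OC)C3)C2)cc1`, differs from compound 3 in one place: 3-methoxypyrrolidin-1-yl in place of (4-methoxycyclohexyl)amino on a carbonyl carbon. For the measured compounds named here, two measured steps bear on this change, since in both of them the same (4-methoxycyclohexyl)amino group is exchanged for a saturated nitrogen ring attached directly to the carbonyl carbon: a 4.2-fold lower number from compound 1 to compound 2 (0.63 log units; beyond the scatter) and the reverse reading a 3.0-fold higher number from compound 2 to compound 3 (0.48 log units; beyond the scatter). Both are modest and beyond the scatter, with the ring-linked amide giving the lower number. The entering 3-methoxypyrrolidin-1-yl group is not the same as 4-(trifluoromethyl)piperidin-1-yl, so the shift is expected to be smaller and less certain. The step is estimated as a 1.7-fold lower number from compound 3 to compound 4 (0.24 log units; within the scatter), a modest lowering. Compound 4 is therefore expected to give about 550 nM in this assay, with a range from 200 nM to 1500 nM.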

Compound 4, half-maximal inhibitory concentration: 2460 nM
Compound 4: the middle estimate sits 4.5-fold (0.65 log units) below what was measured; measured number above the stated range.
By their numbers in this assay, from the lowest: compound 2; then compounds 3, 1 and 4 (each within the scatter of the next, the first and the last beyond it).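

The exchange of the (4-methoxycyclohexyl)amino group for 3-methoxypyrrolidin-1-yl on this carbonyl carbon does not lower the number but raises it, with a 2.6-fold higher number from compound 3 to compound 4 (0.41 log units; beyond the scatter), while the same exchange read against the other stereoisomer gives a 1.8-fold higher number from compound 1 to compound 4 (0.26 log units; within the scatter), so that compound 1 and compound 4 cannot be told apart here. A saturated nitrogen ring attached directly to the carbonyl carbon therefore does not by itself give the lower number, since compound 2 and compound 4 both carry such a ring and stand on opposite sides of the cyclohexylamide pair. The choice of ring and substituent carries real weight at this position, with a 7.7-fold higher number from compound 2 to compound 4 (0.89 log units; beyond the scatter), the largest step among these four compounds.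

Compound 2 and compound 4 differ in both ring size and ring substituent, so the shown compounds do not separate the two, and a 4-methoxypiperidin-1-yl or a 3-(trifluoromethyl)pyrrolidin-1-yl group on the same carbonyl carbon would be needed to do so. Nothing in the data shown gives a reason for the higher number of compound 4.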